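Working notes on compounds 1 to 3

A few compounds are considered here, and "the series" means these few. Any claim that something is new, unique, unknown or untested is made for them only; others in the source may bear on it.

Measured so far:
compound 1 `CCC1(Cc2ccccc2)OS(=O)(=O)C=C1OC` — > 200000 nM (a limit of the assay)
compound 2 `CC(C)C1(Cc2ccccc2)OS(=O)(=O)C=C1OCc1ccccc1` — 200000 nM

In an ADME assay on HEL cells (Homo sapiens) for cytotoxicity, with a stated time of 3 days (on this read-out higher numbers stand for lower toxicity in this test and lower numbers for higher toxicity in this test), compound 1 gives > 200000 nM, which is a limit of the assay and not a number. Compound 1 therefore stands at the limit of > 200000 nM in this assay, at which 1 of the 2 values shown sits, rather than at a measured point. In this assay compound 2 gives 200000 nM. For the measured compounds named here, no step between measured compounds is available. Compound 3 `CCC1(Cc2ccccc2)OS(=O)(=O)C=C1OCc1ccc(C)cc1` differs from compound 1 by 4-methylphenyl in place of hydrogen on a saturated chain carbon bound to an oxygen on an unsaturated carbon. The step from compound 1 to compound 3 in this assay is expected to be a number no higher from compound 1 to compound 3 (the limit leaves the size open), none beyond the scatter. Compound 3 is estimated at 200000 nM, with a range of 80000 nM to 300000 nM.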

Compound 3, half-maximal cytotoxic concentration: 41500 nM
Estimate against measurement, compound 3: 4.8-fold (0.68 log units) above; measured number outside the range, below it.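

In this assay, 4-methylphenyl in place of hydrogen on a saturated chain carbon bound to an oxygen on an unsaturated carbon gives an at least 4.8-fold lower number from compound 1 to compound 3 (0.68 log units; beyond the scatter) and so shows that this position can register higher toxicity in this test. The value of compound 1 is a limit of the assay, so the step has an open size: the limit of > 200000 nM in this assay, at which 1 of the 3 values shown sits.

Going by these compounds, whether the ring or its methyl carries the step stays open. On these data alone, how an amine or a carboxylic acid on that ring would read in this assay also stays open.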